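The source may report more compounds than this note shows. Statements on the series, on what has been measured and on what is new or still open speak of the compounds shown alone.

Three compounds share one core and differ only in the group on an amide-type nitrogen. In a functional assay on L1210 cells (Mus musculus) for inhibition, read by MTT assay, with a stated time of 72 h (a lower number here means a stronger inhibitor, a higher number a weaker inhibitor), compound 1 (`COc1cc(NC(C)CCCNC(=O)Nc2ccc(Br)cc2)c2ncccc2c1`) gives 18000 nM, compound 2 (`COc1cc(NC(C)CCCNC(=O)Nc2ccc(F)cc2)c2ncccc2c1`) gives 18000 nM and compound 3 (`COc1cc(NC(C)CCCNC(=O)Nc2cccc(C(F)(F)F)c2)c2ncccc2c1`) gives 9200 nM. Compound 3 therefore stands within the scatter of both others, as the measured steps show: a 2.0-fold lower number from compound 1 to compound 3 (0.29 log units; within the scatter) and a 2.0-fold lower number from compound 2 to compound 3 (0.29 log units; within the scatter). The exchange of bromo for fluoro likewise shows no change at the digits printed from compound 1 to compound 2 (within the scatter).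

The next compound, compound 4 (`COc1cc(NC(C)CCCNC(=O)Nc2ccc(O)cc2)c2ncccc2c1`), has not yet been measured. It changes the same group again: 4-hydroxyphenyl in place of 3-(trifluoromethyl)phenyl on an amide-type nitrogen. In words, 4-hydroxyphenyl stands in place of 3-(trifluoromethyl)phenyl on an amide-type nitrogen. Among the compounds with values here, no measured compound carries a 4-hydroxyphenyl group, so the data offer no direct precedent. The three measured steps are the nearest evidence, and none of them leaves the scatter. No step beyond the scatter is therefore expected in this assay, and the data argue for no firm direction. The estimated step is a 1.5-fold higher number from compound 3 to compound 4 (0.18 log units; within the scatter), which stays within the scatter. For compound 4 the estimated value is 14000 nM, with an expected range from 6000 nM to 35000 nM.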

Compound 4, half-maximal inhibitory concentration: 21000 nM
Compound 4: middle estimate off by 1.5-fold (0.18 log units), on the low side; low and high end bracket the measured number.
By their numbers in this assay, from the lowest: compounds 3, 1, 2 and 4 (each within the scatter of the next, the first and the last beyond it).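

In this assay, within the data shown here, the exchange of 3-(trifluoromethyl)phenyl for 4-hydroxyphenyl on the amide-type nitrogen gives a 2.3-fold higher number from compound 3 to compound 4 (0.36 log units; beyond the scatter), the first step in this set to leave the scatter, though only modestly. Among these compounds, the two other steps that reach the new compound stay inside the scatter, with a 1.2-fold higher number from compound 2 to compound 4 (0.07 log units; within the scatter) and a 1.2-fold higher number from compound 1 to compound 4 (0.07 log units; within the scatter), so hydroxy on the aromatic carbon cannot be told apart from fluoro or bromo, and the single step beyond the scatter stands only against compound 3, while compound 1, compound 2 and compound 4 remain together. The group at this position has therefore moved the number measurably in one pair, but only by a small amount, and nothing given here accounts for that step.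

The compounds shown leave open whether an amine or a carboxylic acid in place of hydroxy on the aromatic carbon would move the number any further than these groups do. They also leave open whether replacing the aromatic ring on the amide-type nitrogen with a longer alkyl chain would carry the number clearly outside the narrow band seen so far.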